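The compounds below may be only part of what the source reports. "The series", "measured", "known", "first", "only" and "open" are said of these compounds alone.

Measured compounds in a toxicity assay on HEK-293T cells (Homo sapiens) for inhibition, read by MTT assay, with a stated time of 24 h; a higher number here means that more compound is tolerated, a lower number that less compound is tolerated:
- Compound 1, `CCN1CCN(c2c(CO)c(=O)oc3ccccc23)CC1`: compound 1 gives > 50000 nM, which is a limit of the assay rather than a number.
- Compound 2, `O=c1oc2ccccc2c(N2CCN(c3ccc(F)cc3)CC2)c1CO`: compound 2 gives > 50000 nM, again a limit and not a number.
- Compound 3, `COc1ccc(N2CCN(c3c(CO)c(=O)oc4ccccc34)CC2)cc1`: compound 3 gives > 50000 nM, also a limit.

Compound 1 therefore stands at the edge of what this assay can report, and the two other measured compounds stand there with it, as the shared limit shows: the limit of > 50000 nM in this assay, at which 3 of the 3 values shown sit. Because all three values are limits, the steps between them cannot be sized: from compound 1 to compound 2 the step is a step that the two limits leave unreadable from compound 1 to compound 2, from compound 1 to compound 3 it is a step that the two limits leave unreadable from compound 1 to compound 3, and from compound 2 to compound 3 it is a step that the two limits leave unreadable from compound 2 to compound 3.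

The step now followed leads from compound 1 to compound 4, `COc1cccc(N2CCN(c3c(CO)c(=O)oc4ccccc34)CC2)c1`, which has not yet been measured in this assay. The change is 3-methoxyphenyl in place of ethyl on an amine nitrogen in a ring. The two measured steps that swap the same ethyl for an aryl group bear on it most directly, yet neither could be read, so no direction or size beyond the scatter can be expected from them.

Compound 4 is therefore expected to sit at the limit as well, with an estimate of 60000 nM and a range from 30000 nM to 150000 nM. The expected step from compound 1 to compound 4 is a step that the limit leaves unreadable from compound 1 to compound 4.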

Compound 4, half-maximal cytotoxic concentration: > 50000 nM
Compound 4: a limit, no number; the forecaster's own chance of this, stated with the estimate: 85%; the middle value is on the limit's open side.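

None of the steps from compound 1, compound 2 or compound 3 to compound 4 can be read, because all four compounds give a limit and not a number: the limit of > 50000 nM in this assay, at which 4 of the 4 values shown sit.

The compounds shown leave open how much of each is tolerated in this assay beyond that limit, and whether swapping the group on the ring nitrogen changes it at all.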